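Shrinking the Amide Substituent Toward Dimethylcarbamoyl

The source may hold more compounds than are shown below. What is called first, only, known or untested is meant among the compounds shown, and "the series" means these compounds.

The account follows the step from compound 2 to compound 3. Compound 2 `COc1cc(-n2cccc2C(=O)N2CCCC2)ccc1Nc1ncc(Cl)c(Nc2ccccc2NS(C)(=O)=O)n1` holds the only number shown in a functional assay on A549 cells (Homo sapiens) for antiproliferative activity, read by MTT assay, with a stated time of 72 h; on this read-out higher numbers stand for weaker inhibition and lower numbers for stronger inhibition: compound 2 gives 4580 nM. Compound 1 `COc1cc(-n2cccc2C(=O)N2CCCCC2)ccc1Nc1ncc(Cl)c(Nc2ccccc2NS(C)(=O)=O)n1` returns only a limit in this assay, > 10000 nM (the limit of > 10000 nM in this assay, at which 1 of the 2 values shown sits). Within the data shown here, the single measured step, an at least 2.1-fold lower number from compound 1 to compound 2 (0.33 log units; beyond the scatter), came from pyrrolidin-1-yl in place of piperidin-1-yl on a carbonyl carbon. Compound 3 `COc1cc(-n2cccc2C(=O)N(C)C)ccc1Nc1ncc(Cl)c(Nc2ccccc2NS(C)(=O)=O)n1` carries the change (dimethylamino in place of pyrrolidin-1-yl on a carbonyl carbon), cutting the amide substituent further. Among the measured compounds shown here, with only that one step as a guide, a step of about a 1.3-fold lower number from compound 2 to compound 3 (0.12 log units; within the scatter) is expected, likely within the scatter. Compound 3 is therefore estimated at 3500 nM, between 1200 nM and 10000 nM.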

Compound 3, half-maximal inhibitory concentration: > 10000 nM
Compound 3 was reported as a limit (the forecaster's own chance of this, stated with the estimate: 20%); middle value at least 2.8-fold (0.45 log units) away from the limit.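

In this assay, dimethylamino on the carbonyl carbon does not extend the change seen on going from piperidin-1-yl to pyrrolidin-1-yl: the number instead moves the other way, with an at least 2.1-fold higher number from compound 2 to compound 3 (0.33 log units; beyond the scatter) as the step. Of the three amides, only the pyrrolidin-1-yl amide gives a number rather than a limit: the limit of > 10000 nM in this assay, at which 2 of the 3 values shown sit. The step between the two compounds reported as limits cannot be read.

The compounds shown leave open how an azetidine amide, a morpholine amide or a piperazine amide would behave on this carbonyl carbon. They also leave open whether a primary carboxamide would return a number or a limit.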